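The source may hold more compounds than are shown below. What is called first, only, known or untested is meant among the compounds shown, and "the series" means these compounds.

Compound 1 `CCOC(=O)C1=CCCCC1S(=O)(=O)Nc1ccccc1` is the starting point. In a functional assay on RAW264.7 cells (Mus musculus) for inhibition (a higher number here means a weaker inhibitor, a lower number a stronger inhibitor), compound 1 gives 260 nM. Compound 2 `CCOC(=O)C1=CCCCC1S(=O)(=O)Nc1cccc(F)c1` differs from it in one place, (fluoro in place of hydrogen on an aromatic carbon), and in this assay compound 2 gives 150 nM; the step of a 1.7-fold lower number from compound 1 to compound 2 (0.24 log units; within the scatter) is a small one. Compound 3 `CCOC(=O)C1=CCCCC1S(=O)(=O)Nc1ccc(F)cc1F` carries fluoro groups on its aromatic ring; how its core differs from the core of compound 1 is not broken down here. In this assay compound 3 gives 16 nM, the lowest number of the three measured, with its steps to both other compounds beyond the scatter.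

Compound 4 `CCOC(=O)C1=CCCCC1S(=O)(=O)Nc1cc(F)c(F)cc1F` is not yet measured. It differs from compound 3 by fluoro in place of hydrogen on an aromatic carbon. For the measured compounds named here, this is the same kind of change as the one from compound 1 to compound 2, but the surroundings differ: in compound 4 the entering fluoro is ortho to a fluoro group and para to a fluoro group as well as meta to a large group, whereas in compound 2 it was only meta to a large group. Because the earlier step of a 1.7-fold lower number from compound 1 to compound 2 (0.24 log units; within the scatter) stayed within the scatter, only a modest step is expected here, a 1.3-fold lower number from compound 3 to compound 4 (0.12 log units; within the scatter). Compound 4 is therefore estimated at 12 nM in this assay, within a range from 5 nM to 35 nM.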

Compound 4, half-maximal inhibitory concentration: 30 nM
Compound 4: the middle estimate sits 2.5-fold (0.40 log units) below what was measured; the range from low to high includes it.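

Swapping a hydrogen on the aromatic ring for a fluoro does not carry over as one fixed step from core to core in this assay, since the two steps, each small on its own, lie further apart than scatter alone would explain: the same change on two cores in this assay, a 1.7-fold lower number (0.24 log units; within the scatter) from compound 1 to compound 2 and a 1.9-fold higher number (0.27 log units; within the scatter) from compound 3 to compound 4, 3.3-fold (0.51 log units) apart, beyond the scatter of two such steps. The new step, a 1.9-fold higher number from compound 3 to compound 4 (0.27 log units; within the scatter), shows that the added fluoro leaves compound 4 within the scatter of compound 3, so it brings no clear gain or loss on this core. For the compounds shown here, with only one pair on each core, this does not show why the steps part, or whether the place of the entering fluoro or the fluoro groups already on the ring matters more.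

The compounds shown leave open whether a group such as chloro, methyl or methoxy on the same ring would follow either step. They also leave open what happens when the ethyl ester gives way to a carboxylic acid or an amide while the fluoro groups stay.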